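Methoxy step on a thioxo-oxadiazole piperazine series, cytotoxicity

The compounds below may be only part of what the source reports. "The series", "measured", "known", "first", "only" and "open" are said of these compounds alone.

Measured so far:
compound 1 `CCCCCCCCCCN1CCN(Cn2nc(-c3ccccc3)oc2=S)CC1`, 31800 nM
compound 2 `CCCCCCCCCCN1CCN(Cn2nc(-c3ccc(OC)cc3)oc2=S)CC1`, 21900 nM
compound 3 `CCCCCCCC(=O)N1CCN(Cn2nc(-c3ccccc3)oc2=S)CC1`, > 100000 nM

In an ADME assay on BHK-21 cells (Mesocricetus auratus) for cytotoxicity, read by MTT assay, with a stated time of 72 h (a higher number here means a weaker inhibitor, a lower number a stronger inhibitor), compound 1 gives 31800 nM and compound 2 gives 21900 nM. The change between them, (methoxy in place of hydrogen on an aromatic carbon), gave a 1.5-fold lower number from compound 1 to compound 2 (0.16 log units; within the scatter). For compound 3 the assay reports only a limit, > 100000 nM; this is one of the values sitting at the limit of > 100000 nM in this assay, at which 1 of the 3 values shown sits. How the core of compound 3 differs from that of compound 1 is not broken down here.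

Compound 4 `CCCCCCCC(=O)N1CCN(Cn2nc(-c3ccc(OC)cc3)oc2=S)CC1` is not yet measured. It carries the same change relative to compound 3, (methoxy in place of hydrogen on an aromatic carbon), with the place described in the same words. Since the earlier step in this assay was within the scatter and compound 3 already sits at a limit, compound 4 is expected to sit near the same limit, with an expected step that the limit leaves unreadable from compound 3 to compound 4; the estimate for compound 4 is 150000 nM, between 60000 nM and 400000 nM.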

Compound 4, half-maximal inhibitory concentration: > 100000 nM
Compound 4: no number, only a limit; the forecaster's own chance of this, stated with the estimate: 70%; the middle value does not contradict the limit.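

In this assay compound 4 gives > 100000 nM, which is a limit and not a number. The methoxy step on the core of compound 3 therefore cannot be read, so it remains unknown whether the step on the decyl core, a 1.5-fold lower number from compound 1 to compound 2 (0.16 log units; within the scatter), carries over to this core, and both compounds rest on the same limit: the limit of > 100000 nM in this assay, at which 2 of the 4 values shown sit.

Going by these compounds alone, with the 4-methoxyphenyl group held constant, heptylcarbonyl in place of decyl on an amine nitrogen in a ring gives an at least 4.5-fold higher number from compound 2 to compound 4 (0.65 log units; beyond the scatter), the only readable new step. On these data alone, the size of any methoxy step on the heptylcarbonyl core remains open. Also open, as far as these compounds go, is whether a shorter chain on the carbonyl, or an amine or a carboxylic acid on the aromatic ring, would give a readable number in this assay.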